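The source may hold more compounds than are shown below. What is called first, only, known or untested is meant among the compounds shown, and "the series" means these compounds.

Measured in a functional assay on RXF 393 cells (Homo sapiens) for inhibition, read by sulforhodamine B assay, with a stated time of 48 h; on this read-out lower numbers stand for stronger inhibition of growth and higher numbers for weaker inhibition of growth:
compound 1, `COc1ccc(-c2cc(/C=C/C(=O)c3ccc(N)cc3)[nH]n2)cc1`, 1670 nM
compound 2, `COc1ccc(C(=O)/C=C/c2cc(-c3cc(OC)c(OC)c(OC)c3)n[nH]2)cc1OC`, 1350 nM
compound 3, `COc1ccc(C(=O)/C=C/c2cc(-c3cc(OC)c(OC)c(OC)c3)n[nH]2)cc1`, 1270 nM

Compound 1 gives the largest of the three numbers in this assay, but its gap to compound 2 and its gap to compound 3 both lie within the scatter, so the three compounds cannot be separated on these numbers. Compound 4 is `COc1ccc(-c2cc(/C=C/C(=O)c3ccc(N)cc3)[nH]n2)cc1OC` and is not yet measured; it differs from compound 1 by methoxy in place of hydrogen on an aromatic carbon. Among the compounds with values here, the one step known, a 1.1-fold lower number from compound 2 to compound 3 (0.03 log units; within the scatter), is the reverse change, a methoxy removed from an aromatic carbon elsewhere in the shared core, and it lies within the scatter. Within the data shown here, no step on the aromatic carbon that carries the change in compound 4 has been measured. The step that is available gives no sign that adding or removing a methoxy on an aromatic carbon of this core moves the number beyond the scatter, so no change beyond the scatter in this assay is expected from compound 1 to compound 4. Compound 4 is therefore expected at 1600 nM, within a range of 700 nM to 3600 nM. The step this estimate implies, a 1.0-fold lower number from compound 1 to compound 4 (0.02 log units; within the scatter), is expected to stay within the scatter.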

Compound 4, concentration for 50% growth inhibition: 2150 nM
Beside the measured number, compound 4's estimate is 1.3-fold (0.13 log units) below it; low and high end bracket the measured number.
By their numbers in this assay, from the lowest: compounds 3, 2, 1 and 4 (each within the scatter of the next).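

In this assay, the aromatic carbon ortho to a methoxy group and meta to a large group now has a measured step of its own, with methoxy in place of hydrogen: a 1.3-fold higher number from compound 1 to compound 4 (0.11 log units; within the scatter) is the result at this position, and it stays within the scatter. Until now the change had been read only at another aromatic carbon, on a different core, so nothing could be said about this position directly; on the core of compound 1, this carbon now takes a second methoxy without a shift that can be told from scatter. Read in the same direction, as removal of a methoxy, the two available steps also cannot be separated from each other: the same change on two cores in this assay, a 1.1-fold lower number (0.03 log units; within the scatter) from compound 2 to compound 3 and a 1.3-fold lower number (0.11 log units; within the scatter) from compound 4 to compound 1, 1.2-fold (0.08 log units) apart, within the scatter of two such steps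

On these data alone, both steps compare only methoxy with hydrogen, so it remains open whether a hydroxyl, a fluorine or a longer alkoxy chain on this aromatic carbon would move the number beyond the scatter. As far as these compounds go, it also remains open whether any substituent here would matter in a cell line other than the one in this assay.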